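Aryl swap at the sulfonamide end of a shared core

A few compounds are considered here, and "the series" means these few. Any claim that something is new, unique, unknown or untested is made for them only; others in the source may bear on it.

Two compounds share a core and differ only in the aromatic group attached to it. Compound 1 `Cc1noc(C)c1-c1ccc(S(=O)(=O)Nc2ccc3c(c2)CCN(C)CC3)cc1` carries a 3,5-dimethyl-1,2-oxazol-4-yl group; in an assay on isolated protein for displacement of a labelled ligand from 5-hydroxytryptamine receptor 6 (Homo sapiens), read by radioligand binding (on this read-out higher numbers stand for weaker inhibition and lower numbers for stronger inhibition), compound 1 gives 10 nM. Compound 2 `Cc1ccc(-c2ccc(S(=O)(=O)Nc3ccc4c(c3)CCN(C)CC4)cc2)s1` carries a 5-methylthiophen-2-yl group instead, and in this assay compound 2 gives 6.31 nM. The step of a 1.6-fold lower number from compound 1 to compound 2 (0.20 log units; within the scatter) is small, so the numbers of compound 1 and compound 2 cannot be told apart within the usual scatter.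

Compound 3 `CN1CCc2ccc(NS(=O)(=O)c3ccc(-c4ccc(C#N)cc4)cc3)cc2CC1` has not been measured. It differs from compound 2 by 4-cyanophenyl in place of 5-methylthiophen-2-yl on an aromatic carbon. Among the measured compounds shown here, the only measured step that bears on this position is the one from compound 1 to compound 2, where replacing one aromatic group by another of different size and ring type left this assay essentially unchanged. A change at the same place is therefore expected to stay within the scatter, with no clear direction. Compound 3 is thus estimated at 10 nM, in the range 3 nM to 30 nM. The expected step of a 1.6-fold higher number from compound 2 to compound 3 (0.20 log units; within the scatter) is, on this basis, not beyond the scatter.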

Compound 3, inhibition constant: 25.1 nM
The estimate for compound 3 lay 2.5-fold (0.40 log units) below the measured number; the measured number falls inside the stated range.
By their numbers in this assay, from the lowest: compounds 2 and 1 (each within the scatter of the next); then compound 3.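

This position is not indifferent to the aromatic group it carries: in this assay, 4-cyanophenyl brings a 4.0-fold higher number from compound 2 to compound 3 (0.60 log units; beyond the scatter) and a 2.5-fold higher number from compound 1 to compound 3 (0.40 log units; beyond the scatter), so both steps are modest but lie beyond the usual scatter. Compound 3 is therefore the weakest of the three compounds shown, whereas the earlier swap between two different five-membered aromatic groups gave no difference that could be told from the scatter. No evidence is available to explain this loss or to tie it to any feature of the 4-cyanophenyl group.

The change brings in a six-membered aromatic ring of carbon only and a nitrile together, and the compounds shown leave open which of the two goes with the higher number. A plain phenyl group with no nitrile would separate them, and a 4-methoxyphenyl or 4-aminomethylphenyl group would show whether other groups at the far end of that ring read like the nitrile or like the two five-membered groups.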